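Notes on the step from compound 3 to compound 4

The source may report more compounds than this note shows. Statements on the series, on what has been measured and on what is new or still open speak of the compounds shown alone.

Values so far in a functional assay on MCF7 cells (Homo sapiens) for cytotoxicity, read by MTT assay, with a stated time of 72 h (a lower number here means a stronger inhibitor, a higher number a weaker inhibitor), for the series:
- compound 1 `O=C(N/N=C/c1ccc(F)cc1Cl)Nc1cc2c(Nc3ccc(F)c(Cl)c3)ncnc2cc1O[C@H]1CCOC1` gives 32200 nM
- compound 2 `COc1ccc(/C=N/NC(=O)Nc2cc3c(Nc4ccc(F)c(Cl)c4)ncnc3cc2O[C@H]2CCOC2)c(OC)c1OC` gives 33800 nM
- compound 3 `COc1cc2ncnc(Nc3ccc(F)c(Cl)c3)c2cc1NC(=O)N/N=C/c1ccc(F)cc1Cl` gives "not active" (no number reported)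

Compound 3 has no single number, being reported as "not active" (no number reported) in this assay and so holding no measured place against the other two. Compound 4 `COc1cc2ncnc(Nc3ccc(F)c(Cl)c3)c2cc1NC(=O)N/N=C/c1ccc(OC)c(OC)c1OC` differs from compound 3 at one place only, and the change is 2,3,4-trimethoxyphenyl in place of 2-chloro-4-fluorophenyl on a carbon with a double bond to nitrogen with the rest unaltered. Among the compounds with values here, one measured step bears on it: a 1.0-fold higher number from compound 1 to compound 2 (0.02 log units; within the scatter) for the same exchange on a different core, and that step lies within the scatter. No step beyond the scatter is therefore expected from the exchange in this assay even though compound 3 offers no number to start from. Compound 4 is expected to remain weak and may also be reported without a number. Compound 4 is estimated at 50000 nM with 25000 nM to 100000 nM as the expected range.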

Compound 4, half-maximal inhibitory concentration: "not active" (no number reported)
Compound 4: no number reported; the estimate stays without a comparison.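

In this assay compound 3 and compound 4 are both reported as "not active" without a number, and no step can be read between them. The compounds shown leave open how far either lies from compound 1 and compound 2. No evidence bearing on this result is available.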